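The source may hold more compounds than are shown below. What is called first, only, known or untested is meant among the compounds shown, and "the series" means these compounds.

Measured in a functional assay on liver (Rattus norvegicus, strain Sprague-Dawley) for inhibition, with a stated time of 1 h; a lower number here means a stronger inhibitor, a higher number a weaker inhibitor:
- compound 1 `COc1cc(C2Oc3cc([C@H]4Oc5cc(O)cc(O)c5C(=O)[C@@H]4O)ccc3OC2COC(=O)c2cc(OC)c(OC)c(OC)c2)ccc1O` gives 25700 nM
- compound 2 `COc1cc(C2Oc3cc([C@H]4Oc5cc(O)cc(O)c5C(=O)[C@@H]4O)ccc3OC2COC(=O)c2ccc([N+](=O)[O-])cc2)ccc1O` gives 12600 nM

Compound 2 holds the lower of these two numbers, so it is the stronger inhibitor so far. Compound 3 `COc1cc(C2Oc3cc([C@H]4Oc5cc(O)cc(O)c5C(=O)[C@@H]4O)ccc3OC2COC(=O)c2cc([N+](=O)[O-])cc([N+](=O)[O-])c2)ccc1O` keeps the shared core and changes one group: 3,5-dinitrophenyl in place of 4-nitrophenyl on a carbonyl carbon and in words this is 3,5-dinitrophenyl in place of 4-nitrophenyl on a carbonyl carbon. Within the data shown here, the only measured step is a 2.0-fold lower number from compound 1 to compound 2 (0.31 log units; beyond the scatter) and it changed the group at this same place. That single modest step is thin evidence, so only a small further drop in this assay is expected, possibly one within the scatter. The expected change is a 1.4-fold lower number from compound 2 to compound 3 (0.15 log units; within the scatter) as an estimate. The estimate for compound 3 is 9000 nM with an expected range from 4000 nM to 20000 nM around it.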

Compound 3, half-maximal inhibitory concentration: 14600 nM
Estimate against measurement, compound 3: 1.6-fold (0.21 log units) below; measured number inside the range.
By their numbers in this assay, from the lowest: compounds 2, 3 and 1 (each within the scatter of the next, the first and the last beyond it).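

Changing 4-nitrophenyl to 3,5-dinitrophenyl on this carbonyl carbon brings no readable change in this assay, with a 1.2-fold higher number from compound 2 to compound 3 (0.06 log units; within the scatter), so more nitro groups on this ring give no further gain here. Even against 3,4,5-trimethoxyphenyl, 3,5-dinitrophenyl shows only a 1.8-fold lower number from compound 1 to compound 3 (0.25 log units; within the scatter), so the whole range at this position remains narrow. No available evidence explains these numbers.

As far as these compounds go, whether an aromatic ring is needed on this carbonyl carbon remains open. A longer carbon chain, an amine or a carboxylic acid at this place could test that.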